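Amide Partner Swap: Dimethyl-oxazole in Place of Difluorophenyl

This account rests on a few compounds, and the source may have more. Where it says the series, first, only, none or still open, it means among the compounds named here.

Measured so far:
compound 1, `COc1ccc2nc(C)cc(OCCNc3cc(C)cc(C)c3)c2c1`: 33000 nM
compound 2, `COc1ccc2nc(C)cc(OCC(=O)Nc3cc(F)cc(F)c3)c2c1`: 13000 nM

In a physicochemical assay for solubility, in phosphate buffer, measured as kinetic solubility, with a stated time of 1 h, at pH 7.4 (on this read-out higher numbers stand for higher solubility and lower numbers for lower solubility), compound 1 gives 33000 nM and compound 2 gives 13000 nM. Compound 2 stands lowest of the two numbers; the nearest, compound 1, lies higher by more than the usual scatter.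

Compound 3, `COc1ccc2nc(C)cc(OCC(=O)Nc3noc(C)c3C)c2c1`, differs from compound 2 in one place: 4,5-dimethyl-1,2-oxazol-3-yl in place of 3,5-difluorophenyl on an amide-type nitrogen. Among the compounds with values here, no pair of measured compounds shows this change, so there is no measured step to lean on. A moderate rise in this assay is expected, a 2.3-fold higher number from compound 2 to compound 3 (0.36 log units; beyond the scatter), probably beyond the scatter. Compound 3 is estimated at 30000 nM, within 10000 nM to 90000 nM.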

Compound 3, solubility: 196000 nM
Compound 3: middle estimate off by 6.5-fold (0.82 log units), on the low side, and the stated range ends below it.
By their numbers in this assay, from the lowest: compound 2; then compound 1; then compound 3.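

In this assay, the group on this amide-type nitrogen turns out to have a strong hold on the read-out: 4,5-dimethyl-1,2-oxazol-3-yl in place of 3,5-difluorophenyl gives a 15-fold higher number from compound 2 to compound 3 (1.18 log units; beyond the scatter) for a single change. The shared core and the amide link stay the same across this step, so the rise goes with the exchanged group. No measurement here accounts for the size of this rise.

Still open, from the compounds shown here alone, is whether the rise follows the ring itself or its two methyl groups. Going by these compounds, how a pyridine ring or an unsubstituted 1,2-oxazol-3-yl would behave on this nitrogen also remains unknown.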